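Acyl chain variation on the pyrazoline series: compound 4

The compounds below may be only part of what the source reports. "The series", "measured", "known", "first", "only" and "open" are said of these compounds alone.

Compound 3 `CN(C)c1ccc(C2CC(c3ccc(-n4cncn4)cc3)=NN2C(=O)CCCl)cc1` gives -0.7% in a functional assay on NCI-H1975 cells (Homo sapiens) for inhibition, read by sulforhodamine B assay, tested at 10 uM (on this read-out higher numbers stand for more inhibition at the one concentration tested (going by the name of the read-out) and lower numbers for less inhibition), the second highest of three numbers, all within the scatter of one another. Compound 2 `CC(=O)N1N=C(c2ccc(-n3cncn3)cc2)CC1c1ccc(N(C)C)cc1` gives -0.3% in this assay, and compound 1 `COC(=O)CC(=O)N1N=C(c2ccc(N3CCN(C)CC3)cc2)CC1c1ccc(N(C)C)cc1` gives -2.2%. Compound 4 `COC(=O)CC(=O)N1N=C(c2ccc(-n3cncn3)cc2)CC1c1ccc(N(C)C)cc1` differs from compound 3 by methoxycarbonyl in place of chloromethyl on a saturated chain carbon bound to a carbonyl carbon. Among the compounds with values here, the only step at this place, a number 0.4 percentage points lower from compound 2 to compound 3 (within the scatter), lay within the scatter, and compound 1, which carries the methoxycarbonyl chain of compound 4, sits within the scatter of compound 3 as well. No step beyond the scatter is therefore expected, and the expected step is a number 0.3 percentage points lower from compound 3 to compound 4 (within the scatter). Compound 4 is estimated at -1%, with a range from -8% to 6%.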

Compound 4, a percentage reported as inhibition, at one concentration (the size of the read-out at that concentration, not a potency): 1.5%
For compound 4 the middle estimate is 2.5 percentage points below the measured one; the range from low to high includes it.
By their numbers in this assay, from the lowest: compounds 1, 3, 2 and 4 (each within the scatter of the next).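

In this assay, methoxycarbonyl on a saturated chain carbon bound to a carbonyl carbon reads within the scatter of both chloromethyl (a number 2.2 percentage points higher from compound 3 to compound 4 (within the scatter)) and hydrogen (a number 1.8 percentage points higher from compound 2 to compound 4 (within the scatter)), so all three groups at this place now read alike. The change on an aromatic carbon, 1H-1,2,4-triazol-1-yl in place of 4-methylpiperazin-1-yl, also stays within the scatter (a number 3.7 percentage points higher from compound 1 to compound 4 (within the scatter)). No data are at hand that bear on why these numbers read alike.

On these data alone, whether an amine, a carboxylic acid or a longer chain at this place would give a step beyond the scatter stays open. The same holds for a morpholine ring in place of 1H-1,2,4-triazol-1-yl on the aromatic carbon.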